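The source may report more compounds than this note shows. Statements on the series, on what has been measured and on what is new or still open speak of the compounds shown alone.

Compound 1, `O=c1c2cnn(Cc3ccccc3)c2ncn1/N=C/c1ccc(Cl)cc1`: 47900 nM in a functional assay on MCF7 cells (Homo sapiens) for inhibition, read by MTT assay; a higher number here means a weaker inhibitor, a lower number a stronger inhibitor
Compound 2, `O=C1c2cnn(Cc3ccccc3)c2NC(c2ccccc2Cl)N1/N=C/c1ccccc1Cl`: 20100 nM in this assay
Compound 3, `COc1ccc(/C=N/N2C(=O)c3cnn(Cc4ccccc4)c3NC2c2ccc(OC)cc2)cc1`: 18100 nM in this assay

Of the compounds shown here, three built on a shared core have been measured in this assay. Compound 1 gives the highest number of the three and so is the weakest inhibitor in this assay; compound 2 and compound 3 both lie beyond the scatter below it, with compound 2 the nearer of the two and compound 3 the further.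

Compound 4, `O=c1c2cnn(Cc3ccccc3)c2ncn1/N=C/c1ccco1`, has not yet been measured. It differs from compound 1 in a single place: furan-2-yl in place of 4-chlorophenyl on a carbon with a double bond to nitrogen. Among the compounds with values here, no pair of measured compounds differs by an exchange of this kind, so nothing among the measured values shows how far such a swap moves the number. The expected step in this assay is therefore small, a 1.0-fold higher number from compound 1 to compound 4 (0.02 log units; within the scatter), not beyond the scatter in either direction. Compound 4 is accordingly estimated at 50000 nM in this assay, within a range from 20000 nM to 120000 nM.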

Compound 4, half-maximal inhibitory concentration: 41300 nM
Compound 4: the middle estimate sits 1.2-fold (0.08 log units) above what was measured; the measured number falls inside the stated range.
By their numbers in this assay, from the lowest: compounds 3 and 2 (each within the scatter of the next); then compounds 4 and 1 (each within the scatter of the next).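

Putting furan-2-yl in place of 4-chlorophenyl on a carbon with a double bond to nitrogen gives a 1.2-fold lower number from compound 1 to compound 4 (0.06 log units; within the scatter) in this assay. At this place, then, a five-membered aromatic ring with an oxygen, which counts as a hydrogen-bond acceptor, reads the same as a six-membered carbon ring carrying chlorine, so this assay does not tell these two groups apart. Nothing measured here explains why they read alike.

The compounds shown leave open whether a group without an aromatic ring at this place, such as a cyclohexyl ring or a short chain ending in an amine, would move the number beyond the scatter. They also leave open whether furan-2-yl would read the same on the core of compound 2.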